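The source may hold more compounds than are shown below. What is called first, only, known or untested is meant among the compounds shown, and "the series" means these compounds.

Measured compounds in a functional assay on HCT-116 cells (Homo sapiens) for inhibition, read by MTT assay, with a stated time of 48 h; a higher number here means a weaker inhibitor, a lower number a stronger inhibitor:
Compound 1, `Clc1cccc(CSc2nnc(-c3ccncc3)n2-c2ccccc2)c1`, gives 9820 nM.
Compound 2, `Fc1ccc(CSc2nnc(-c3ccncc3)n2-c2ccccc2)c(F)c1`, gives 11400 nM.
Compound 3, `O=C(CSc1nnc(-c2ccncc2)n1-c1ccccc1)N/N=C/c1ccc(O)cc1`, gives only a limit of the assay, > 50000 nM.

Compound 3 thus stands at the limit described by the limit of > 50000 nM in this assay, at which 1 of the 3 values shown sits; its number is not known, and it sits apart from compound 1 and compound 2, which have measured values on the same core. Among the measured compounds shown here, the only measured step, a 1.2-fold higher number from compound 1 to compound 2 (0.06 log units; within the scatter), concerns an exchange on the saturated chain carbon bound to sulfur and is within the scatter, so it says nothing about the change considered here. Compound 4, `O=C(CSc1nnc(-c2ccncc2)n1-c1ccccc1)N/N=C/C=C/c1ccccc1`, differs from compound 3 as follows: 2-phenylethenyl in place of 4-hydroxyphenyl on a carbon with a double bond to nitrogen. For the measured compounds named here, no measured pair shares this exchange, and no measured compound carries the longer chain of compound 3 with a known number, so the size of the step cannot be read from the data. Compound 4 is expected to remain weak, with an estimated 40000 nM in this assay, ranging from 10000 nM to 150000 nM. The expected step, an at least 1.2-fold lower number from compound 3 to compound 4 (0.09 log units; that floor lies within the scatter), is an estimate carrying a high chance that compound 4 again reaches only the limit.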

Compound 4, half-maximal inhibitory concentration: 6150 nM
Estimate against measurement, compound 4: 6.5-fold (0.81 log units) above; measured number outside the range, below it.
By their numbers in this assay, from the lowest: compounds 4, 1 and 2 (each within the scatter of the next). At a limit, above all of these: compound 3.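

In this assay, the group on a carbon with a double bond to nitrogen can change the read-out: an at least 8.1-fold lower number from compound 3 to compound 4 (0.91 log units; beyond the scatter). Among the compounds shown here, no earlier step had gone beyond the scatter, and compound 4, at 6150 nM, shows that the longer chain shared with compound 3 does not by itself rule out a measured number. Compound 3 has only a limit of the assay, not a number, so the full size of the step stays unknown: the limit of > 50000 nM in this assay, at which 1 of the 4 values shown sits.

The exchange removes the hydroxy-bearing ring and brings in the double bond together, and these two changes cannot be told apart here. From the compounds shown here alone, it remains open how a plain phenyl group or a saturated phenylethyl chain would behave in this place.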